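The source may hold more compounds than are shown below. What is called first, only, known or untested is meant among the compounds shown, and "the series" means these compounds.

Measured compounds:
- compound 1, `CN1CCN(c2ccc(Nc3ncc4nc(Nc5ccc(F)cc5)n(CCNS(=O)(=O)C5CC5)c4n3)cc2)CC1`: 50 nM
- compound 2, `CC(=O)N1CC[C@H](n2c(Nc3ccccc3)nc3cnc(Nc4ccc(N5CCN(C)CC5)cc4)nc32)C1`: 260 nM

In a functional assay on HCC827 cells (Homo sapiens) for antiproliferative activity, read by MTT assay, with a stated time of 72 h (a higher number here means a weaker inhibitor, a lower number a stronger inhibitor), compound 1 gives 50 nM, the lowest number of the two measured here. Compound 2 gives 260 nM in this assay, a higher number that lies beyond the usual scatter, so compound 2 is the weaker inhibitor of the pair.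

Compound 3, `CCOC(=O)CN1CC[C@H](n2c(Nc3ccc(F)cc3)nc3cnc(Nc4ccc(N5CCN(C)CC5)cc4)nc32)C1`, has not yet been measured. It differs from compound 1 at one place: 1-((ethoxycarbonyl)methyl)pyrrolidin-3-yl in place of 2-((cyclopropylsulfonyl)amino)ethyl on an aromatic nitrogen. Among the compounds with values here, no measured pair shows this exact change, so its effect is not known from the data. With a new group of this kind entering on the shared core, the step from compound 1 to compound 3 in this assay is expected to be a modest rise in the number, about a 3.0-fold higher number from compound 1 to compound 3 (0.48 log units; beyond the scatter). Compound 3 is thus expected to give about 150 nM, within a range of 50 nM to 450 nM.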

Compound 3, half-maximal inhibitory concentration: 1810 nM
For compound 3 the middle estimate is 12-fold (1.08 log units) below the measured one; the whole stated range lies below it.
By their numbers in this assay, from the lowest: compound 1; then compound 2; then compound 3.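

In this assay, putting 1-((ethoxycarbonyl)methyl)pyrrolidin-3-yl in place of 2-((cyclopropylsulfonyl)amino)ethyl on the aromatic nitrogen gives a 36-fold higher number from compound 1 to compound 3 (1.56 log units; beyond the scatter), so on this core the group at this position can shift the number by a large amount. Compound 1 and compound 2 differ in more than one place, which makes this the only pair shown that isolates a change at this nitrogen. Nothing measured here accounts for the size of this step.

The whole side chain changes in this single step, so the pair cannot separate the part played by the cyclopropylsulfonyl amino unit, the pyrrolidine ring and the ethyl ester. A carboxylic acid in place of the ethyl ester, or a pyrrolidine carrying a free amine, would help to tell these parts apart.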